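3-Bromophenyl for 4-methoxyphenyl in a small cytotoxic series

The source may report more compounds than this note shows. Statements on the series, on what has been measured and on what is new or still open speak of the compounds shown alone.

In a functional assay on MCF7 cells (Homo sapiens) for cytotoxicity, read by MTT assay, with a stated time of 24 h (a lower number here means a stronger inhibitor, a higher number a weaker inhibitor), compound 1 (`COc1cc(/C=C(\C#N)C(=O)N/N=C(\C)c2c(O)c3ccc(O)cc3oc2=O)ccc1O`) gives 13700 nM and compound 2 (`COc1ccc(/C=C(\C#N)C(=O)N/N=C(\C)c2c(O)c3ccc(O)cc3oc2=O)cc1`) gives 8940 nM while compound 3 (`COc1cc(/C=C(\C#N)C(=O)N/N=C(\C)c2c(O)c3ccc(O)cc3oc2=O)cc(OC)c1OC`) gives 11300 nM on the same shared core. Compound 2 therefore stands within the scatter of both other compounds, and the three numbers set no order among them. Compound 4 (`C/C(=N\NC(=O)/C(C#N)=C/c1cccc(Br)c1)c1c(O)c2ccc(O)cc2oc1=O`), not yet measured, keeps that core and carries 3-bromophenyl in place of 4-methoxyphenyl on a double-bonded chain carbon bound to a double-bonded chain carbon, a change counted as 3-bromophenyl in place of 4-methoxyphenyl on a double-bonded chain carbon bound to a double-bonded chain carbon in full. Within the data shown here, the one measured step at that place shows a 1.5-fold lower number from compound 1 to compound 2 (0.19 log units; within the scatter) and so gives no sign of a large response. Among the measured compounds shown here, no measured compound carries bromine, so this evidence is indirect. The estimated step is a 1.1-fold higher number from compound 2 to compound 4 (0.03 log units; within the scatter), and no change beyond the scatter is expected in this assay in either direction. For compound 4 the estimated value is 9500 nM with an expected range from 4000 nM to 22000 nM in this measurement.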

Compound 4, half-maximal inhibitory concentration: 19600 nM
For compound 4 the middle estimate is 2.1-fold (0.31 log units) below the measured one; the measured number falls inside the stated range.
By their numbers in this assay, from the lowest: compounds 2, 3, 1 and 4 (each within the scatter of the next, the first and the last beyond it).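

In this assay this place on the double-bonded chain carbon is shown to respond: 3-bromophenyl in place of 4-methoxyphenyl gives a 2.2-fold higher number from compound 2 to compound 4 (0.34 log units; beyond the scatter) and is the only step here beyond the scatter, though a modest one. Set against 4-hydroxy-3-methoxyphenyl, the same group gives a 1.4-fold higher number from compound 1 to compound 4 (0.16 log units; within the scatter) and no change can be claimed, so the reading depends on which group is replaced. Nothing given here accounts for this step.

Since the step removes the methoxy group and adds bromine at once, the compounds do not separate the two. On these data alone, whether an amine or a carboxylic acid on this phenyl ring would move the number in either direction also remains open.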